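Terminal ring variation on the shared core

A few compounds are considered here, and "the series" means these few. Any claim that something is new, unique, unknown or untested is made for them only; others in the source may bear on it.

Measured so far in an in vitro assay on CHO cells for displacement of a labelled ligand from Bombesin receptor subtype-3 (Homo sapiens), read by scintillation counting, with a stated time of 2 h; a higher number here means a weaker inhibitor, a lower number a stronger inhibitor:
compound 1 `CCC(C)(C)Cc1c[nH]c(CCc2ccc(-c3ccncc3)cc2)n1` gives 101 nM
compound 2 `CCC(C)(C)Cc1c[nH]c(CCc2ccc(-c3csnn3)cc2)n1` gives 45 nM
compound 3 `CCC(C)(C)Cc1c[nH]c(CCc2ccc(-c3ccns3)cc2)n1` gives 11 nM

Compound 3 stands lowest of the three numbers in this assay: the step from compound 2 is a 4.1-fold lower number from compound 2 to compound 3 (0.61 log units; beyond the scatter), and the wider one a 9.2-fold lower number from compound 1 to compound 3 (0.96 log units; beyond the scatter). Compound 4 `CCC(C)(C)Cc1c[nH]c(CCc2ccc(-c3ccccc3C(=O)O)cc2)n1` is the next point on this ring position; the change is 2-carboxyphenyl in place of 1,2-thiazol-5-yl on an aromatic carbon.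

All three measured steps alter this same terminal ring and so bear on the change: a 2.2-fold lower number from compound 1 to compound 2 (0.35 log units; beyond the scatter), a 9.2-fold lower number from compound 1 to compound 3 (0.96 log units; beyond the scatter) and a 4.1-fold lower number from compound 2 to compound 3 (0.61 log units; beyond the scatter), each modest and each beyond the scatter. None of them brings in a six-membered aromatic ring of carbon only or a hydrogen-bond donor, so direction is uncertain. The one six-membered ring in the set, pyridin-4-yl in compound 1, sits at the highest number, 101 nM. A higher number is therefore expected for compound 4, with a step of about a 10-fold higher number from compound 3 to compound 4 (1.00 log units; beyond the scatter). The estimate for compound 4 in this assay is 110 nM, within a range of 25 nM to 500 nM.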

Compound 4, half-maximal inhibitory concentration: 11 nM
Compound 4: middle estimate off by 10-fold (1.00 log units), on the high side; measured number below the stated range.
By their numbers in this assay, from the lowest: compounds 3 and 4 (each within the scatter of the next); then compound 2; then compound 1.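

In this assay, a six-membered aromatic ring of carbon only with a carboxylic acid on it, 9 heavy atoms against 5 for the 1,2-thiazol-5-yl ring, fits this position with no change at the digits printed from compound 3 to compound 4 (within the scatter). The same group gives a 4.1-fold lower number from compound 2 to compound 4 (0.61 log units; beyond the scatter) and a 9.2-fold lower number from compound 1 to compound 4 (0.96 log units; beyond the scatter), so the high number of the pyridin-4-yl compound does not extend to every six-membered ring at this position, and a hydrogen-bond donor on the ring is compatible with the low end of the series. No measurement in hand accounts for this result.

From the compounds shown here alone, what the carboxylic acid adds on its own remains open, and a plain phenyl ring or the methyl ester would separate it from the ring. Also open, going by these compounds, is whether 3-carboxyphenyl or 4-carboxyphenyl would match 2-carboxyphenyl in this assay.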